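The source may hold more compounds than are shown below. What is called first, only, known or untested is meant among the compounds shown, and "the series" means these compounds.

Compound 1 `CC(C)(C)OC(=O)CNC(=O)c1[nH]cnc1C(=O)Nc1ccc(Cl)c(Cl)c1`: 25400 nM
Compound 2 `C[C@H](NC(=O)c1[nH]cnc1C(=O)Nc1ccc(Cl)c(Cl)c1)C(=O)OC(C)(C)C`: 2400 nM

In a functional assay on HL-60 cells (Homo sapiens), with a stated time of 4 days (on this read-out lower numbers stand for stronger inhibition and higher numbers for weaker inhibition), compound 2 holds the lower of the two numbers and compound 1 the higher. Going by the values given here, the one measured step, an 11-fold lower number from compound 1 to compound 2 (1.02 log units; beyond the scatter), came with methyl in place of hydrogen on a saturated chain carbon bound to an amide-type nitrogen and a carbonyl carbon. Compound 3 `COC(=O)[C@@H](NC(=O)c1[nH]cnc1C(=O)Nc1ccc(Cl)c(Cl)c1)C(C)C` is unmeasured; it differs from compound 2 by 1-(methoxycarbonyl)-2-methylpropyl in place of 1-(tert-butoxycarbonyl)ethyl on an amide-type nitrogen. This change touches the same chain carbon as the measured step but also exchanges the ester, for which no measurement exists. Compound 3 is therefore expected to sit near compound 2, with only a small estimated step of a 1.6-fold lower number from compound 2 to compound 3 (0.20 log units; within the scatter). Compound 3 is estimated at 1500 nM, within 400 nM to 6000 nM.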

Compound 3, half-maximal inhibitory concentration: > 62500 nM
Compound 3: no number, only a limit (the forecaster's own chance of this, stated with the estimate: 5%); middle value at least 41-fold (1.61 log units) away from the limit.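

In this assay compound 3 carries no number, only a limit: the limit of > 62500 nM in this assay, at which 1 of the 3 values shown sits. On the amide-type nitrogen, 1-(methoxycarbonyl)-2-methylpropyl in place of 1-(tert-butoxycarbonyl)ethyl gives an at least 26-fold higher number from compound 2 to compound 3 (1.41 log units; beyond the scatter), so a change at this position can also move the number sharply upward, opposite to the methyl step. The same group in place of (tert-butoxycarbonyl)methyl gives an at least 2.4-fold higher number from compound 1 to compound 3 (0.39 log units; beyond the scatter), which puts this change on the weak side of both earlier groups.

The chain and the ester change together here, so the compounds shown cannot assign the loss to either one. Going by these compounds, how a carboxylic acid in place of the ester would read out also remains open.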